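This account rests on a few compounds, and the source may have more. Where it says the series, first, only, none or still open, it means among the compounds named here.

- compound 1 `COc1ccc(/C=C/C(=O)Nc2cc3c(Nc4ccc(F)c(Cl)c4)ncnc3cc2O[C@H]2CCOC2)c(OC)c1` at 26500 nM in the series
- compound 2 `O=C(/C=C/c1cc(Br)c(O)c(Br)c1)Nc1cc2c(Nc3ccc(F)c(Cl)c3)ncnc2cc1O[C@H]1CCOC1` at 27700 nM in the series

In a functional assay on HeLa cells (Homo sapiens) for cytotoxicity, read by MTT assay, with a stated time of 72 h (on this read-out higher numbers stand for weaker inhibition and lower numbers for stronger inhibition), compound 2 stands at 27700 nM and level with compound 1, within the scatter. Compound 3 `O=C(/C=C/c1ccccc1[N+](=O)[O-])Nc1cc2c(Nc3ccc(F)c(Cl)c3)ncnc2cc1O[C@H]1CCOC1` has 2-nitrophenyl in place of 3,5-dibromo-4-hydroxyphenyl on a double-bonded chain carbon bound to a double-bonded chain carbon. Among the measured compounds shown here, the one measured step at this place, with a 1.0-fold higher number from compound 1 to compound 2 (0.02 log units; within the scatter) as its size, lies within the scatter, though it exchanges a different pair of groups. No step beyond the scatter is therefore expected in this assay here. The estimated step is a 1.3-fold lower number from compound 2 to compound 3 (0.10 log units; within the scatter) at this place. Compound 3 is thus estimated at 22000 nM with an expected range of 9000 nM to 50000 nM for this measurement.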

Compound 3, half-maximal inhibitory concentration: 29600 nM
For compound 3 the middle estimate is 1.3-fold (0.13 log units) below the measured one; the range from low to high includes it.
By their numbers in this assay, from the lowest: compounds 1, 2 and 3 (each within the scatter of the next).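

In this assay the change to 2-nitrophenyl gives a 1.1-fold higher number from compound 2 to compound 3 (0.03 log units; within the scatter) and also a 1.1-fold higher number from compound 1 to compound 3 (0.05 log units; within the scatter) and so extends the flat picture at this place to a third substituted phenyl group. Across these compounds, 2-nitrophenyl, 3,5-dibromo-4-hydroxyphenyl and 2,4-dimethoxyphenyl on a double-bonded chain carbon bound to a double-bonded chain carbon remain level, even though the entering group has no hydrogen-bond donor and the 3,5-dibromo-4-hydroxyphenyl group has one. No measured evidence bears on this flat response. Still open, as far as these compounds go, is whether a dimethylamino or carboxylic acid substituent on the phenyl ring would give a step beyond the scatter. All three compounds share one core, so the flat response is shown for that core alone.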